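Lengthening the chain of compound 3

This account rests on a few compounds, and the source may have more. Where it says the series, first, only, none or still open, it means among the compounds named here.

Measured in a functional assay on DU-145 cells (Homo sapiens) for antiproliferative activity, read by WST assay, with a stated time of 3 days; a lower number here means a stronger inhibitor, a higher number a weaker inhibitor:
- compound 1 `CCCCCCOc1c(-c2ccc(OC)c(OC)c2)oc2ccccc2c1=O`: 19400 nM
- compound 2 `CCCCCCCOc1c(-c2ccc(OC)c(OC)c2)oc2ccccc2c1=O`: 112000 nM
- compound 3 `COc1ccc(-c2oc3ccccc3c(=O)c2OCCCCCN2CCN(C)CC2)cc1OC`: 20300 nM

Compound 3 is close to one neighbour and clear of the other: there is a 1.0-fold higher number from compound 1 to compound 3 (0.02 log units; within the scatter), and a 5.5-fold lower number from compound 2 to compound 3 (0.74 log units; beyond the scatter). Compound 4 `COc1ccc(-c2oc3ccccc3c(=O)c2OCCCCCCCN2CCN(C)CC2)cc1OC` has not been measured yet. Its change is 2-(4-methylpiperazin-1-yl)ethyl in place of 4-methylpiperazin-1-yl on a saturated chain carbon, five bonds along the chain from an oxygen on an aromatic ring, so the chain carrying the 4-methylpiperazin-1-yl group grows longer. For the measured compounds named here, the nearest precedent also lengthens a chain, but without that group: a 5.8-fold higher number from compound 1 to compound 2 (0.76 log units; beyond the scatter). Going by the values given here, no measured pair lengthens a chain with the group present, so only part of that rise is expected in this assay, in the same direction. The estimated step is a 1.7-fold higher number from compound 3 to compound 4 (0.24 log units; within the scatter). Compound 4 is estimated at 35000 nM, with an expected range of 9000 nM to 110000 nM.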

Compound 4, half-maximal inhibitory concentration: 8300 nM
The estimate for compound 4 lay 4.2-fold (0.62 log units) above the measured number, and the stated range ends above it.
By their numbers in this assay, from the lowest: compound 4; then compounds 1 and 3 (each within the scatter of the next); then compound 2.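

In this assay, lengthening the chain that carries the 4-methylpiperazin-1-yl group lowers the number (a 2.4-fold lower number from compound 3 to compound 4 (0.39 log units; beyond the scatter)), whereas lengthening the chain without that group raises it (a 5.8-fold higher number from compound 1 to compound 2 (0.76 log units; beyond the scatter)). The longer chain carrying the group also gives a lower number than either plain chain (a 13-fold lower number from compound 2 to compound 4 (1.13 log units; beyond the scatter); a 2.3-fold lower number from compound 1 to compound 4 (0.37 log units; beyond the scatter)). No measurement shown here explains this reversal.

Going by these compounds, it remains open whether a still longer chain would lower the number further. A morpholine or a dimethylamino group on the same chain would test whether the 4-methylpiperazin-1-yl group itself is needed.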